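Removing a methoxy from the far end of compound 2

The compounds below may be only part of what the source reports. "The series", "measured", "known", "first", "only" and "open" are said of these compounds alone.

Among the compounds with values here, the three compounds measured so far share one long core and differ only in the group carried on the aromatic ring next to the sulfoxide. Compound 1 `COc1ccc(CCCCCCCCOc2ccc(C[S+]([O-])c3cccc(CS(=O)(=O)C(F)(F)F)c3)nc2/C=C/C(=O)O)cc1` gives 225 nM in an assay for binding affinity to leukotriene B4 receptor 1 (Homo sapiens); a higher number here means a weaker inhibitor, a lower number a stronger inhibitor. Compound 2 `COc1ccc(CCCCCCCCOc2ccc(C[S+]([O-])c3cccc(N)c3)nc2/C=C/C(=O)O)cc1` gives 4.7 nM, and compound 3 `COc1ccc(CCCCCCCCOc2ccc(C[S+]([O-])c3cccc(N(C)C)c3)nc2/C=C/C(=O)O)cc1` gives 245 nM. Compound 2 stands lowest of the three: the step of a 48-fold lower number from compound 1 to compound 2 (1.68 log units; beyond the scatter) and the step of a 52-fold higher number from compound 2 to compound 3 (1.72 log units; beyond the scatter) are both large, while a 1.1-fold higher number from compound 1 to compound 3 (0.04 log units; within the scatter) is within the scatter.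

Compound 4 `Nc1cccc([S+]([O-])Cc2ccc(OCCCCCCCCc3ccccc3)c(/C=C/C(=O)O)n2)c1` keeps the amino group of compound 2 and changes the opposite end of the molecule instead: hydrogen in place of methoxy on an aromatic carbon. Within the data shown here, none of the measured steps touches this end; all three concern the amino-bearing ring, so they say nothing direct about the methoxy. What they do show is that a group at one end of this core can move the binding number a great deal, which leaves the outcome here open.

Among the measured compounds shown here, with no comparable step available, the expectation is that compound 4 stays near compound 2, with a step of a 1.7-fold higher number from compound 2 to compound 4 (0.23 log units; within the scatter) that may not rise beyond the scatter. Compound 4 is therefore estimated at 8 nM, between 2.5 nM and 30 nM.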

Compound 4, inhibition constant: 11 nM
Estimate against measurement, compound 4: 1.4-fold (0.14 log units) below; the range from low to high includes it.
By their numbers in this assay, from the lowest: compound 2; then compound 4; then compounds 1 and 3 (each within the scatter of the next).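

Within the data shown here, changing 4-methoxyphenyl to phenyl in this assay gives a 2.3-fold higher number from compound 2 to compound 4 (0.37 log units; beyond the scatter) and shows that this end of the molecule affects the binding number, a point the earlier compounds could not address. The effect is modest, however: the steps of a 48-fold lower number from compound 1 to compound 2 (1.68 log units; beyond the scatter) and a 52-fold higher number from compound 2 to compound 3 (1.72 log units; beyond the scatter) at the amino-bearing ring are both much larger, so compound 2 does not owe most of its low number to the methoxy. Nothing available here explains why removing the methoxy raises the number.

The compounds shown leave open whether a hydroxy, a fluorine or an ethoxy in place of the methoxy would give a number closer to that of compound 2 or compound 4, and therefore whether the oxygen, the methyl or simply the size of the group matters. They also leave open whether the same change would have a similar effect with the dimethylamino group of compound 3, or with a shorter or longer chain joining the two ends of the molecule.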